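From 1H-pyrazol-4-yl to 6-amino-5-methylpyridin-3-yl

The compounds below may be only part of what the source reports. "The series", "measured", "known", "first", "only" and "open" are said of these compounds alone.

Two compounds have numbers in an in vitro assay on HEK385-7 cells for displacement of a labelled ligand from prostaglandin D2 receptor 2 (Homo sapiens); on this read-out higher numbers stand for weaker inhibition and lower numbers for stronger inhibition. Compound 1 `O=C(O)Cc1sc(NCc2ccccc2)nc1-c1ccc(Cl)cc1` gives 440 nM, while compound 2 `O=C(O)Cc1sc(C(c2ccc(F)cc2)c2ccc(F)cc2)nc1-c1cn[nH]c1` gives 16 nM. Among the compounds with values here, compound 2 therefore holds the lowest number of the two; compound 1, its only neighbour, sits well beyond the scatter above it, so compound 2 is the stronger binder of the pair.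

Compound 3 `Cc1cc(-c2nc(C(c3ccc(F)cc3)c3ccc(F)cc3)sc2CC(=O)O)cnc1N` is the next step from compound 2, and its change is 6-amino-5-methylpyridin-3-yl in place of 1H-pyrazol-4-yl on an aromatic carbon. The group that leaves and the group that enters occupy the same place on the shared core, and nothing measured here shows what such an exchange does to binding. The step from compound 2 is expected to stay small, with no clear direction beyond the scatter: a 1.6-fold higher number from compound 2 to compound 3 (0.19 log units; within the scatter). For compound 3 the estimate in this assay is 25 nM, within a range from 6 nM to 100 nM.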

Compound 3, half-maximal inhibitory concentration: 880 nM
Beside the measured number, compound 3's estimate is 35-fold (1.55 log units) below it; measured number outside the range, above it.
By their numbers in this assay, from the lowest: compound 2; then compounds 1 and 3 (each within the scatter of the next).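

On the aromatic carbon next to the ring nitrogen, the aromatic group clearly matters for binding: in this assay, putting 6-amino-5-methylpyridin-3-yl in place of 1H-pyrazol-4-yl gives a 55-fold higher number from compound 2 to compound 3 (1.74 log units; beyond the scatter). So this position does not treat these two aromatic groups alike, and here the six-membered ring with its two added substituents goes with much weaker inhibition than the five-membered ring. Nothing available explains this drop in binding.

The exchange alters the ring size, the ring atoms and the substituents in a single step, so the compounds shown cannot separate what each of these contributes. On these data alone, a plain pyridine ring, carrying neither the amino nor the methyl group, would sit between compound 2 and compound 3 in structure, and its effect on binding remains open.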